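This account rests on a few compounds, and the source may have more. Where it says the series, first, only, none or still open, it means among the compounds named here.

Measured so far in a functional assay on HeLa cells (Homo sapiens) for inhibition; on this read-out lower numbers stand for stronger inhibition and higher numbers for weaker inhibition:

compound 1, `CC(=O)OCCOn1cnc2c(Cl)nc(N)nc21`: > 500000 nM (a limit, not a number)

compound 2, `CC(=O)OC(C)n1cnc2c(Cl)nc(I)nc21`: 5130 nM

compound 3, `CC(=O)OCCOn1cnc2c(Cl)nc(I)nc21`: 398000 nM

In this assay compound 1 sits at the limit of > 500000 nM in this assay, at which 1 of the 3 values shown sits. For compound 1 no number is therefore known, only a limit. Compound 2 and compound 3 give measured numbers. The only recorded step among these three, an at least 1.2-fold lower number from compound 1 to compound 3 (0.09 log units; that floor lies within the scatter), concerns the exchange of the amino group for iodo and says nothing about the position changed in compound 4.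

Compound 4, `CC(=O)OCCOn1cnc2c(S)nc(N)nc21`, differs from compound 1 by sulfanyl in place of chloro on an aromatic carbon. Within the data shown here, none of the measured steps bears on this exchange: the chloro group is kept in compound 1, compound 2 and compound 3 alike, and sulfanyl appears in none of them. Because compound 1 stands at the limit of > 500000 nM in this assay, at which 1 of the 3 values shown sits, the starting point of this step is itself not a number, so no size can be derived for it.

Compound 4 is therefore expected near 500000 nM, between 100000 nM and 2500000 nM, with a substantial chance that this assay again reports only a limit. The step of a number no higher from compound 1 to compound 4 (the limit leaves the size open) is expected to be none beyond the scatter.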

Compound 4, half-maximal inhibitory concentration: 5000 nM
Compound 4: the middle estimate sits 100-fold (2.00 log units) above what was measured; measured number below the stated range.
By their numbers in this assay, from the lowest: compounds 4 and 2 (each within the scatter of the next); then compound 3. At a limit, above all of these: compound 1.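

In this assay the aromatic carbon next to the ring nitrogen turns out to be a place where a single-atom exchange matters: sulfanyl in place of chloro gives an at least 100-fold lower number from compound 1 to compound 4 (2.00 log units; beyond the scatter). Among these compounds, compounds 1, 2 and 3 all keep the chloro group at this place, so they could show only what happens elsewhere on the molecule, and this is the first step that tests this position, with the amino group and the side chain of compound 1 left unchanged. Compound 1 has a limit and not a number, so the size of this step is a floor and the full change remains unknown: the limit of > 500000 nM in this assay, at which 1 of the 4 values shown sits.

The exchange swaps chlorine for sulfur and also adds a hydrogen-bond donor and a hydrogen-bond acceptor to the count, and the compounds shown cannot separate these differences, a question that a hydroxyl group or a methylsulfanyl group at the same place would bear on. Going by these compounds, it also remains open whether sulfanyl has a similar effect when iodo replaces the amino group, as in compound 3, whose value of 398000 nM offers a measured starting point for such a comparison.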